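Swapping the 5-bromofuran-2-yl group of compound 2 for 5-methylthiophen-2-yl

The source may report more compounds than this note shows. Statements on the series, on what has been measured and on what is new or still open speak of the compounds shown alone.

In a functional assay on PC-3 cells (Homo sapiens) for inhibition, read by MTT assay (on this read-out lower numbers stand for stronger inhibition and higher numbers for weaker inhibition), compound 1 `Cc1ccc(-c2nnc(NC(=O)CCCCCCC(=O)NO)s2)o1` gives 880 nM and compound 2 `O=C(CCCCCCC(=O)Nc1nnc(-c2ccc(Br)o2)s1)NO` gives 880 nM. Going by the values given here, compound 2 therefore stands level with compound 1, its only measured neighbour.

The next step leads to compound 3 `Cc1ccc(-c2nnc(NC(=O)CCCCCCC(=O)NO)s2)s1`, which has not yet been measured: 5-methylthiophen-2-yl in place of 5-bromofuran-2-yl on an aromatic carbon. Here 5-methylthiophen-2-yl comes in place of 5-bromofuran-2-yl on an aromatic carbon, and the rest of the structure stays the same.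

Among the compounds with values here, one measured step bears on this change: no change at the digits printed from compound 1 to compound 2 (within the scatter). It exchanged methyl and bromo on an aromatic carbon, and its size lies within the scatter. Compound 3 carries the methyl again, so that part of the change has a measured precedent. Within the data shown here, no measured step isolates the exchange of ring oxygen for ring sulfur, which leaves the main uncertainty there. No step beyond the scatter is expected in this assay, and no direction is favoured. The estimated step is a 1.1-fold lower number from compound 2 to compound 3 (0.04 log units; within the scatter). For compound 3 the estimated value is 800 nM, with an expected range from 300 nM to 2100 nM.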

Compound 3, half-maximal inhibitory concentration: 880 nM
Compound 3: middle estimate off by 1.1-fold (0.04 log units), on the low side; low and high end bracket the measured number.
By their numbers in this assay, from the lowest: compounds 1, 2 and 3 (each within the scatter of the next).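

The exchange of 5-bromofuran-2-yl for 5-methylthiophen-2-yl in this assay shows no change at the digits printed from compound 2 to compound 3 (within the scatter) even though both the ring hetero atom and the group on that ring differ at once. The step that keeps the methyl and exchanges only ring oxygen for ring sulfur shows no change at the digits printed from compound 1 to compound 3 (within the scatter) and supplies what the earlier pair lacked, since that pair covered only methyl against bromo on the furan, so at this place on the core both exchanges tried so far leave the read-out level. Nothing on hand gives a reason for this flat result.

Three compounds with level values cannot tell whether this position tolerates change in general or whether these two ring types and two small groups simply happen to match, and 5-bromothiophen-2-yl would complete the set of pairings. Groups further from these, such as an amine or a carboxylic acid on the ring, a plain phenyl ring in place of the five-membered ring, or a longer chain in that same place, remain the open test of whether this position can shift the number at all.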